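Aryl variation on the imidazole nitrogen of the chromone series

The source may hold more compounds than are shown below. What is called first, only, known or untested is meant among the compounds shown, and "the series" means these compounds.

Measured so far:
- compound 1 `COc1ccccc1-n1c(-c2coc3cc(C)c(Cl)cc3c2=O)nc(-c2ccccc2)c1-c1ccccc1`: 25000 nM
- compound 2 `Cc1ccc(-n2c(-c3coc4cc(C)c(Cl)cc4c3=O)nc(-c3ccccc3)c2-c2ccccc2)c(C)c1`: 6250 nM
- compound 3 `Cc1cc2occ(-c3nc(-c4ccccc4)c(-c4ccccc4)n3-c3ccc(Br)cc3)c(=O)c2cc1Cl`: 1560 nM

Compound 2 sits second highest of the three numbers in a functional assay on MCF7 cells (Homo sapiens) for inhibition, read by MTT assay, with a stated time of 72 h; a higher number here means a weaker inhibitor, a lower number a stronger inhibitor; compound 1 lies above it by a 4.0-fold lower number from compound 1 to compound 2 (0.60 log units; beyond the scatter) and compound 3 below it by a 4.0-fold lower number from compound 2 to compound 3 (0.60 log units; beyond the scatter). Compound 4 `Cc1cc2occ(-c3nc(-c4ccccc4)c(-c4ccccc4)n3-c3cccc(Cl)c3)c(=O)c2cc1Cl` is not yet measured; it differs from compound 2 in this way: 3-chlorophenyl in place of 2,4-dimethylphenyl on an aromatic nitrogen.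

Among the measured compounds shown here, the step that bears most directly on this change is the one from compound 2 to compound 3, where a halogen-bearing phenyl replaced the 2,4-dimethylphenyl and gave a 4.0-fold lower number from compound 2 to compound 3 (0.60 log units; beyond the scatter). The step of a 16-fold lower number from compound 1 to compound 3 (1.20 log units; beyond the scatter) points the same way, though it starts from compound 1. Compound 4 carries its chlorine on the 3-position rather than the 4-position of compound 3, so a smaller gain is expected here than that seen for compound 3, and the expected step is a 2.5-fold lower number from compound 2 to compound 4 (0.40 log units; beyond the scatter). Compound 4 is therefore estimated at 2500 nM, with a range from 1000 nM to 6500 nM in this assay.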

Compound 4, half-maximal inhibitory concentration: 6250 nM
For compound 4 the middle estimate is 2.5-fold (0.40 log units) below the measured one, and the stated range covers the measured number.
By their numbers in this assay, from the lowest: compound 3; then compounds 2 and 4 (each within the scatter of the next); then compound 1.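

In this assay, a halogen on the aromatic nitrogen's phenyl group does not by itself separate the series from the 2,4-dimethylphenyl compound, with no change at the digits printed from compound 2 to compound 4 (within the scatter), while 3-chlorophenyl in place of 4-bromophenyl gives a 4.0-fold higher number from compound 3 to compound 4 (0.60 log units; beyond the scatter), so the low value of compound 3 is not shared by every halogen-bearing phenyl shown. Against the 2-methoxyphenyl group, 3-chlorophenyl still gives a 4.0-fold lower number from compound 1 to compound 4 (0.60 log units; beyond the scatter), the same size of step as the one seen earlier for 2,4-dimethylphenyl. No supporting data bear on why these aryl groups differ.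

Compound 3 and compound 4 differ in both the halogen and its place on the phenyl. Separating the two would need 4-chlorophenyl and 3-bromophenyl groups. Going by these compounds, whether a phenyl carrying an amine or a carboxylic acid fits this trend also remains open.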